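The source may hold more compounds than are shown below. What is called first, only, known or untested is meant among the compounds shown, and "the series" means these compounds.

Measured compounds: compound 1 `COc1cc(C)cc(-c2c(-c3ccnc(-c4ccc(C(C)=O)cc4)c3)cnn2CC#N)c1` with > 100000 nM; compound 2 `COc1cc(C)cc(-c2nn(CC#N)cc2-c2ccc(-c3cccc(C(C)=O)c3)nc2)c1` with > 100000 nM; compound 3 `COc1cc(C)cc(-c2nn(CC#N)cc2-c2ccnc(-c3ccc(N(C)C)cc3)c2)c1` with > 100000 nM.

In a functional assay on T47D cells (Homo sapiens) for inhibition, read by sulforhodamine B assay, with a stated time of 48 h (on this read-out lower numbers stand for higher toxicity in this test and higher numbers for lower toxicity in this test), compound 1 reaches only the limit of the test, > 100000 nM, not a number. Compound 2 likewise stops at the limit, > 100000 nM. Compound 3 also stops at the limit, > 100000 nM. So compound 1 stands nowhere in particular: all three shown values sit at the same limit, (the limit of > 100000 nM in this assay, at which 3 of the 3 values shown sit), and none separates from the others.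

Compound 4 `COc1cc(C)cc(-c2c(-c3ccnc(-c4ccc(N(C)C)cc4)c3)cnn2CC#N)c1` differs from compound 1 by dimethylamino in place of acetyl on an aromatic carbon. With every shown value at the limit, no step in this assay is visible to build on, and the expectation is a step from compound 1 to compound 4 of no size beyond the scatter, a step that the limit leaves unreadable from compound 1 to compound 4. Compound 4 is thus expected again at the limit, estimated at 150000 nM, between 50000 nM and 500000 nM.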

Compound 4, concentration lethal to 50% of the cells: > 100000 nM
Compound 4: a limit, no number; the forecaster's own chance of this, stated with the estimate: 85%; the middle value is on the limit's open side.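

Compound 1 and compound 4 both stop at a limit of this assay, not at a number, so no step between them can be read: the limit of > 100000 nM in this assay, at which 4 of the 4 values shown sit.

Whether dimethylamino in place of acetyl changes the result at all, and where any of the compounds shown truly lies, stays open.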